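A few compounds are considered here, and "the series" means these few. Any claim that something is new, unique, unknown or untested is made for them only; others in the source may bear on it.

Compound 2, `CCC(=O)c1ccccc1CC[C@H](SC[C@@H](C)C(=O)O)c1cccc(/C=C/c2ccc3ccc(Cl)cc3n2)c1`, was assayed in an assay on membranes from lung for inhibition of cysteinyl leukotriene receptor 1 (Cavia porcellus) (on this read-out higher numbers stand for weaker inhibition and lower numbers for stronger inhibition), where compound 2 gives 3.7 nM. Among the measured compounds shown here, of the two numbers measured so far, compound 2 holds the higher one. For the measured compounds named here, its nearest neighbour is compound 1, `C[C@H](CS[C@@H](CCc1cccc(CO)c1)c1cccc(/C=C/c2ccc3ccc(Cl)cc3n2)c1)C(=O)O`, which in this assay gives 2.1 nM; the single measured step, a 1.8-fold higher number from compound 1 to compound 2 (0.25 log units; within the scatter), replaces 3-(hydroxymethyl)phenyl with 2-propanoylphenyl on the saturated chain carbon and stays within the scatter.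

Compound 3, `C[C@H](CS[C@@H](CCc1ccccc1C(=O)c1ccccc1)c1cccc(/C=C/c2ccc3ccc(Cl)cc3n2)c1)C(=O)O`, has not yet been measured. It differs from compound 2 in one place: phenyl in place of ethyl on a carbonyl carbon.

Going by the values given here, no measured step touches the carbonyl carbon itself, so nothing in the data bears directly on exchanging ethyl for phenyl there. Among the compounds with values here, the only step available, a 1.8-fold higher number from compound 1 to compound 2 (0.25 log units; within the scatter), shows that a larger change at the end of the chain left the number within the scatter, and it is taken here as a loose guide that the shared core of compound 2 sets the number. The step expected for compound 3 is therefore a 1.1-fold higher number from compound 2 to compound 3 (0.03 log units; within the scatter), with no direction beyond the scatter. The estimate for compound 3 in this assay is 4 nM, between 1.5 nM and 12 nM.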

Compound 3, half-maximal inhibitory concentration: 4.3 nM
Estimate against measurement, compound 3: 1.1-fold (0.03 log units) below; measured number inside the range.
By their numbers in this assay, from the lowest: compounds 1, 2 and 3 (each within the scatter of the next, the first and the last beyond it).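

On the carbonyl carbon, whose other neighbour is an aromatic carbon, the change from propanoyl to benzoyl replaces ethyl, with 2 heavy atoms and no ring, by phenyl, with 6 heavy atoms and one six-membered aromatic ring, and in this assay it gives a 1.2-fold higher number from compound 2 to compound 3 (0.07 log units; within the scatter) and stays within the scatter. The earlier step exchanged the whole aryl group at the end of the chain, whereas this one alters only the group on the carbonyl carbon, and it shows that in this series this place accepts an added aromatic ring with no change in the number that can be told from the scatter. No other kind of measurement accompanies these numbers, so the data offer no account of why the number holds across this change.

On these data alone, with only ethyl and phenyl seen on this carbonyl carbon, it remains open whether a longer chain, an amine or a phenyl carrying a carboxylic acid would also leave the number within the scatter. It also remains open whether the carbonyl itself matters, since no compound shown has a hydroxyl-bearing carbon in its place alongside the phenyl.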